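Moving an ethoxy group on an inactive series

The source may report more compounds than this note shows. Statements on the series, on what has been measured and on what is new or still open speak of the compounds shown alone.

Two members of one series share a large core. Compound 1 `Cc1ccccc1-n1nncc1CN1C(=O)C2(C(C#N)=C(N)Oc3c(N)cc4nc5ccccc5nc4c32)c2ccccc21` carries a 2-methylphenyl group on an aromatic nitrogen. In a functional assay on HCT-116 cells (Homo sapiens) for antiproliferative activity, read by MTT assay, with a stated time of 48 h (on this read-out higher numbers stand for weaker inhibition and lower numbers for stronger inhibition), compound 1 gives > 50000 nM, which is a limit of the assay and not a number. Compound 2 `CCOc1ccc(-n2nncc2CN2C(=O)C3(C(C#N)=C(N)Oc4c(N)cc5nc6ccccc6nc5c43)c3ccccc32)cc1` carries a 4-ethoxyphenyl group in the same place. In this assay compound 2 gives > 50000 nM, again a limit rather than a number. The step that the two limits leave unreadable from compound 1 to compound 2 therefore cannot be read. Compound 3 `CCOc1ccccc1-n1nncc1CN1C(=O)C2(C(C#N)=C(N)Oc3c(N)cc4nc5ccccc5nc4c32)c2ccccc21` has not yet been measured; it differs from compound 2 by 2-ethoxyphenyl in place of 4-ethoxyphenyl on an aromatic nitrogen. Going by the values given here, the only pointer is the limit of > 50000 nM in this assay, at which 2 of the 2 values shown sit, which leaves no measured step that would point either way for the change from compound 2 to compound 3. Compound 3 is thus expected to stay at or near that limit, with an estimated 50000 nM in this assay, within 15000 nM to 200000 nM. The expected step of a number no higher from compound 2 to compound 3 (the limit leaves the size open) is accordingly small.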

Compound 3, half-maximal inhibitory concentration: > 50000 nM
Compound 3 ended at the assay's limit (the forecaster's own chance of this, stated with the estimate: 75%); the middle value lies on the limit itself.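

In this assay compound 3 gives > 50000 nM, a limit and not a number, so the steps to it from compound 1 and compound 2 cannot be read: the limit of > 50000 nM in this assay, at which 3 of the 3 values shown sit.

The compounds shown leave open whether compound 1, compound 2 and compound 3 truly differ from one another in this assay.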